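The source may report more compounds than this note shows. Statements on the series, on what has been measured and on what is new or still open speak of the compounds shown alone.

Three acrylamide-bearing compounds share one core. Compound 1, `C=CC(=O)Nc1cccc(Nc2ncnc(Nc3ccc(C(=O)Nc4ccccn4)cc3)n2)c1`, stands in a functional assay on Ramos cells (Homo sapiens) for antiproliferative activity, read by CCK-8 assay, with a stated time of 24 h (on this read-out lower numbers stand for stronger inhibition and higher numbers for weaker inhibition), as "not determined" (no result reported). Compound 2, `C=CC(=O)Nc1cccc(Nc2nc(N)nc(Nc3ccc(OCCOC)cc3)n2)c1`, gives 18900 nM in this assay. Compound 3, `C=CC(=O)Nc1cccc(Nc2ncnc(Nc3ccc(-c4ccc(Cl)nc4)cc3)n2)c1`, gives 160000 nM in this assay, which is the higher of the two numbers reported, and the gap to compound 2 lies beyond the scatter, so compound 3 is the weaker inhibitor of the two measured compounds.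

Compound 4, `C=CC(=O)Nc1cccc(Nc2ncnc(Nc3ccc(OCCOC)cc3)n2)c1`, is the next compound to be measured. It differs from compound 3 in one place: 2-methoxyethoxy in place of 6-chloropyridin-3-yl on an aromatic carbon. Among the compounds with values here, no measured pair shows this exact change, so its size must be guessed. Compound 2 carries the same 2-methoxyethoxy group on the same ring and gives 18900 nM, which suggests that the group is compatible with a lower number than the chloropyridinyl of compound 3. On that basis the step from compound 3 to compound 4 is expected to lower the number markedly, as a 6.4-fold lower number from compound 3 to compound 4 (0.81 log units; beyond the scatter). Compound 4 is therefore estimated to give 25000 nM in this assay, within a range of 6000 nM to 100000 nM.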

Compound 4, half-maximal inhibitory concentration: 181000 nM
The estimate for compound 4 lay 7.2-fold (0.86 log units) below the measured number, outside the stated range (above it).
By their numbers in this assay, from the lowest: compound 2; then compounds 3 and 4 (each within the scatter of the next).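

Exchanging 6-chloropyridin-3-yl for 2-methoxyethoxy on this aromatic carbon gives in this assay a 1.1-fold higher number from compound 3 to compound 4 (0.05 log units; within the scatter) and so no readable change, although a ring gives way to an open chain. The larger step lies elsewhere on the molecule: hydrogen in place of amino gives a 9.6-fold higher number from compound 2 to compound 4 (0.98 log units; beyond the scatter) and shows that the lower number of compound 2 goes with its amino group, not with the 2-methoxyethoxy group that compound 2 and compound 4 share. Nothing measured here explains either step.

Still open, from the compounds shown here alone, is whether an amine or a carboxylic acid at this position would shift the number, or whether a longer chain would. Going by these compounds, it is also open whether the amino group would lower the number with 6-chloropyridin-3-yl in place.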